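Swapping isobutyl for isopropoxy on a fused bicyclic sulfonamide

A few compounds are considered here, and "the series" means these few. Any claim that something is new, unique, unknown or untested is made for them only; others in the source may bear on it.

Of the compounds shown here, two built on the same fused two-ring core have been tested in a functional assay on the whole organism (uterus, Rattus norvegicus, strain Wistar) for inhibition, tested at 100 uM; a lower number here means a stronger effect, a higher number a weaker effect of the compound at the concentration tested. Compound 1 `CC(C)SC1=NS(=O)(=O)c2cc(Cl)ccc2N1` carries an isopropylsulfanyl group on a carbon with a double bond to nitrogen, and in this assay compound 1 gives 2.3%. Compound 2 `CC(C)CC1=NS(=O)(=O)c2cc(Cl)ccc2N1` carries an isobutyl group in that same place, and in this assay compound 2 gives 55%. Within the data shown here, of the two numbers measured, that of compound 2 is the higher one, and the only step known so far, a number 52.7 percentage points higher from compound 1 to compound 2 (beyond the scatter), separates it from compound 1.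

Compound 3 `CC(C)OC1=NS(=O)(=O)c2cc(Cl)ccc2N1` is not yet measured. It differs from compound 2 in one place: isopropoxy in place of isobutyl on a carbon with a double bond to nitrogen. Among the measured compounds shown here, the entering isopropoxy group shares its branching and its single heteroatom link with the isopropylsulfanyl group of compound 1, so the one relevant step, a number 52.7 percentage points higher from compound 1 to compound 2 (beyond the scatter), suggests that reversing the direction may bring the number back down, though how far is unknown. Compound 3 is therefore expected to give 20%, within a range of 0% to 60%, an estimated step of a number 35 percentage points lower from compound 2 to compound 3 (beyond the scatter).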

Compound 3, a percentage reported as activity, at one concentration (the size of the read-out at that concentration, not a potency) in the Rattus norvegicus assay: 68.7%
Compound 3: the middle estimate sits 48.7 percentage points below what was measured, and the stated range ends below it.
By their numbers in the Rattus norvegicus assay, from the lowest: compound 1; then compound 2; then compound 3.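

The isopropoxy group does not stand in for the isopropylsulfanyl group at this position. In the Rattus norvegicus assay there is a number 66.4 percentage points higher from compound 1 to compound 3 (beyond the scatter), so exchanging the sulfur link for an oxygen link on the same branched group matters a great deal, and there is also a number 13.7 percentage points higher from compound 2 to compound 3 (beyond the scatter), which leaves compound 1 with the strongest effect of the three at the concentration tested. In a physicochemical assay for acid dissociation, compound 2 gives 8.52 and compound 3 gives 8, so this change makes the proton easier to give up, but a single pair cannot tell whether that shift has any link to the weaker effect: the measured acid dissociation constant of compound 2, 8.52, and of compound 3, 8, a number 0.52 log units lower (beyond the scatter)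

Going by these compounds, whether the strong effect of compound 1 depends on the sulfur link alone or on the sulfur link together with its isopropyl group remains open. A smaller methylsulfanyl group, a longer butylsulfanyl chain or an amine on this carbon would help to separate these possibilities, and the compounds shown cannot say how any of them would behave.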